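Methyl for chloro on the benzoyl ring of a quinazoline thiosemicarbazide

A few compounds are considered here, and "the series" means these few. Any claim that something is new, unique, unknown or untested is made for them only; others in the source may bear on it.

Three measured compounds share one core and differ only in the benzoyl ring. In a functional assay on KB cells (Homo sapiens) for cytotoxicity, read by MTT assay, with a stated time of 72 h (on this read-out higher numbers stand for weaker inhibition and lower numbers for stronger inhibition), compound 1 `O=C(NC(=S)NNc1ncnc2ccccc12)c1ccc(Cl)cc1` gives 3940 nM. Compound 2 `Cc1ccc(C(=O)NC(=S)NNc2ncnc3ccccc23)cc1`, which carries methyl in place of chloro on an aromatic carbon, gives 10100 nM in this assay, so that a 2.6-fold higher number from compound 1 to compound 2 (0.41 log units; beyond the scatter). Compound 3 `O=C(NC(=S)NNc1ncnc2ccccc12)c1ccccc1Cl` differs from compound 1 in that the two have the same atoms joined differently, namely (2-chlorophenyl in place of 4-chlorophenyl on a carbonyl carbon); in this assay compound 3 gives 7710 nM, and a 2.0-fold higher number from compound 1 to compound 3 (0.29 log units; within the scatter), while a 1.3-fold lower number from compound 2 to compound 3 (0.12 log units; within the scatter).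

Compound 4 `Cc1ccccc1C(=O)NC(=S)NNc1ncnc2ccccc12` has not yet been measured. It differs from compound 3 by methyl in place of chloro on an aromatic carbon. This is the same kind of change as that from compound 1 to compound 2, but the place differs: there the methyl sits para to a large group, here ortho to a large group. Resting on compound 3 at 7710 nM and on the step of a 2.6-fold higher number from compound 1 to compound 2 (0.41 log units; beyond the scatter), the account expects a step of about a 2.1-fold higher number from compound 3 to compound 4 (0.32 log units; beyond the scatter) in this assay, with wide room given that the change is known from a single pair. Compound 4 is therefore estimated at 16000 nM, between 6000 nM and 45000 nM.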

Compound 4, half-maximal inhibitory concentration: 2770 nM
Compound 4: the middle estimate sits 5.8-fold (0.76 log units) above what was measured, outside the stated range (below it).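

In this assay, methyl in place of chloro does not carry over from the 4-chlorophenyl compounds to the 2-chlorophenyl compounds, since the step changes direction: the same change on two cores in this assay, a 2.6-fold higher number (0.41 log units; beyond the scatter) from compound 1 to compound 2 and a 2.8-fold lower number (0.44 log units; beyond the scatter) from compound 3 to compound 4, 7.1-fold (0.85 log units) apart, beyond the scatter of two such steps. With the methyl ortho to a large group the swap gives a 2.8-fold lower number from compound 3 to compound 4 (0.44 log units; beyond the scatter), moving the methyl alone gives a 3.6-fold lower number from compound 2 to compound 4 (0.56 log units; beyond the scatter), and a 1.4-fold lower number from compound 1 to compound 4 (0.15 log units; within the scatter) marks no real difference. This shows that in these four compounds the outcome of the swap depends on where it is made, but each direction rests on a single pair, so it gives no rule for other places on the ring and does not explain why the two steps differ.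

The compounds shown leave open whether a methoxy, an amine or a longer chain such as ethyl in the same place would follow methyl or chloro. They also leave open how a plain phenyl without any such group compares with these four.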